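A few compounds are considered here, and "the series" means these few. Any claim that something is new, unique, unknown or untested is made for them only; others in the source may bear on it.

Compound 3 `CCCCn1cc(COc2cc(O)c3c(c2)O[C@H](c2ccc(OC)c(O)c2)CC3=O)nn1` carries a propyl on a saturated chain carbon bound to an aromatic nitrogen, where compound 1 `COc1ccc([C@@H]2CC(=O)c3c(O)cc(OCc4cn(Cc5ccc(C(F)(F)F)cc5)nn4)cc3O2)cc1O` carries a 4-(trifluoromethyl)phenyl and compound 2 `COc1ccc([C@@H]2CC(=O)c3c(O)cc(OCc4cn(Cc5ccccc5)nn4)cc3O2)cc1O` a phenyl. In a functional assay on RAW264.7 cells (Mus musculus) for inhibition, read by Griess assay, with stated times of 2 h and 24 h (a lower number here means a stronger inhibitor, a higher number a weaker inhibitor), compound 1 gives 17700 nM; in this assay compound 2 gives 11000 nM, and compound 3 gives 13900 nM. All three numbers lie within the scatter of one another, so compound 3 stands among them without a readable difference: a 1.3-fold lower number from compound 1 to compound 3 (0.10 log units; within the scatter), a 1.3-fold higher number from compound 2 to compound 3 (0.10 log units; within the scatter), and a 1.6-fold lower number from compound 1 to compound 2 (0.21 log units; within the scatter).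

Compound 4 `COc1ccc([C@@H]2CC(=O)c3c(O)cc(OCc4cn(Cc5cccc(C(F)(F)F)c5)nn4)cc3O2)cc1O` differs from compound 3 by 3-(trifluoromethyl)phenyl in place of propyl on a saturated chain carbon bound to an aromatic nitrogen. Within the data shown here, the steps that bear on this change are the exchange of propyl for 4-(trifluoromethyl)phenyl, a 1.3-fold lower number from compound 1 to compound 3 (0.10 log units; within the scatter), and for phenyl, a 1.3-fold higher number from compound 2 to compound 3 (0.10 log units; within the scatter), both within the scatter. The step to compound 4 in this assay is therefore expected to be no larger than the scatter, in no definite direction, a 1.1-fold higher number from compound 3 to compound 4 (0.03 log units; within the scatter). Compound 4 is accordingly estimated at 15000 nM, with a range from 7000 nM to 32000 nM.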

Compound 4, half-maximal inhibitory concentration: 19900 nM
Compound 4: middle estimate off by 1.3-fold (0.12 log units), on the low side; the range from low to high includes it.
By their numbers in this assay, from the lowest: compounds 2, 3, 1 and 4 (each within the scatter of the next).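

At this place, on a saturated chain carbon bound to an aromatic nitrogen, a ring-bearing 3-(trifluoromethyl)phenyl in place of the open-chain propyl makes no readable difference in this assay, with a 1.4-fold higher number from compound 3 to compound 4 (0.16 log units; within the scatter) as the step. The same holds for trifluoromethyl in place of hydrogen on an aromatic carbon, which gives a 1.8-fold higher number from compound 2 to compound 4 (0.26 log units; within the scatter) and remains within the scatter, and for 3-(trifluoromethyl)phenyl in place of 4-(trifluoromethyl)phenyl, which gives a 1.1-fold higher number from compound 1 to compound 4 (0.05 log units; within the scatter) and likewise shows no readable difference. All four compounds thus stand within the scatter of one another, and no evidence bearing on this result is at hand.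

On these data alone, whether an amine or a carboxylic acid at this place would separate from these four numbers stays open. So does the outcome of a nitrile in place of the trifluoromethyl on the aromatic ring.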